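Aryl variation on the shared core: expectation for compound 3

The source may report more compounds than this note shows. Statements on the series, on what has been measured and on what is new or still open speak of the compounds shown alone.

Compound 1, `c1ccc2c(-c3cn4ccnc4c(-c4ccc5ncn(C6CCCCC6)c5c4)n3)cccc2c1`: 6.92%
Compound 2, `Fc1ccc(-c2cn3ccnc3c(-c3ccc4ncn(C5CCCCC5)c4c3)n2)cc1`: 20.4%

In a functional assay on SR cells (Homo sapiens) for inhibition, read by sulforhodamine B assay, with a stated time of 48 h, tested at 10 uM (on this read-out lower numbers stand for less inhibition and higher numbers for more inhibition at the one concentration tested (going by the name of the read-out)), compound 2 gives 20.4%, the highest of the two numbers shown; compound 1 gives 6.92%. Among the compounds with values here, the one measured step, a number 13.5 percentage points higher from compound 1 to compound 2 (beyond the scatter), exchanged the aryl group on the shared core. Compound 3, `c1cn2cc(-c3ccsc3)nc(-c3ccc4ncn(C5CCCCC5)c4c3)c2n1`, carries thiophen-3-yl in place of 4-fluorophenyl on an aromatic carbon. Within the data shown here, only the step from compound 1 to compound 2 bears on this change, and only loosely: it exchanged naphthalen-1-yl for 4-fluorophenyl and was modest, whereas here thiophen-3-yl replaces 4-fluorophenyl. Among the measured compounds shown here, no measured pair shows a five-membered aromatic ring at this place. The expectation is therefore a step of a number 5.4 percentage points lower from compound 2 to compound 3 (within the scatter) from compound 2 to compound 3, within the scatter or a little lower. Compound 3 is estimated at 15%, with a range from 0% to 35%.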

Compound 3, a percentage reported as inhibition, at one concentration (the size of the read-out at that concentration, not a potency): 14.3%
Compound 3: middle estimate off by 0.7 percentage points, on the high side, and the stated range covers the measured number.
By their numbers in this assay, from the lowest: compounds 1, 3 and 2 (each within the scatter of the next, the first and the last beyond it).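

In this assay this place now carries a five-membered aromatic ring with 1 hetero atom, and thiophen-3-yl gives a number 6.1 percentage points lower from compound 2 to compound 3 (within the scatter) and also a number 7.4 percentage points higher from compound 1 to compound 3 (within the scatter), so it cannot be told apart from either 4-fluorophenyl or naphthalen-1-yl. Within the data shown here, the only step beyond the scatter at this place remains the one between those two larger groups, and a change of ring size here, with fluorine leaving and sulfur entering, gives no readable difference from 4-fluorophenyl. Nothing available explains these numbers.

Open, going by these compounds, is whether an amine such as morpholine or a carboxylic acid at this place, in place of an aromatic ring, would move the number beyond the scatter. Also open, on these data alone, is how these three aryl groups would compare with a group other than cyclohexyl on the far ring nitrogen.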